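Dichlorobenzyl for cyanobenzyl: expected cytotoxicity of compound 3

A few compounds are considered here, and "the series" means these few. Any claim that something is new, unique, unknown or untested is made for them only; others in the source may bear on it.

Compound 1 `N#Cc1ccccc1CN1C(=O)N(Cc2cccc(Cl)c2)S(=O)(=O)n2cccc21`: > 293000 nM
Compound 2 `N#Cc1ccccc1CN1C(=O)N(Cc2ccccc2)S(=O)(=O)n2cccc21`: > 318000 nM

In an ADME assay on MT4 cells (Homo sapiens) for cytotoxicity, read by MTT assay, with a stated time of 5 days (a lower number here means that less compound is tolerated, a higher number that more compound is tolerated), compound 1 gives > 293000 nM, which is a limit of the assay and not a number. Compound 2 gives > 318000 nM, likewise a limit. The step that the two limits leave unreadable from compound 1 to compound 2 is therefore unreadable, as both results sit at limits (the limit of > 293000 nM in this assay, at which 1 of the 2 values shown sits, and (the limit of > 318000 nM in this assay, at which 1 of the 2 values shown sits)). Compound 3 `O=C1N(Cc2ccc(Cl)cc2Cl)c2cccn2S(=O)(=O)N1Cc1cccc(Cl)c1` differs from compound 1 by 2,4-dichlorophenyl in place of 2-cyanophenyl on a saturated chain carbon bound to an amide-type nitrogen in a ring. Going by the values given here, no measured step touches this position, and the only measured step is unreadable in size and direction. Among the compounds with values here, compound 1 stands at a limit, with the one further value also a limit. The writer therefore expects compound 3 to show no step beyond the scatter and estimates an at least 1.1-fold lower number from compound 1 to compound 3 (0.06 log units; that floor lies within the scatter). For compound 3 the estimated value is 250000 nM, expected to lie between 80000 nM and 320000 nM, most likely again reported as a limit.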

Compound 3, half-maximal cytotoxic concentration: > 251000 nM
Compound 3: no number, only a limit; the forecaster's own chance of this, stated with the estimate: 70%; at least 1.0-fold (0.00 log units) between middle value and limit.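

In this assay compound 3 gives > 251000 nM, a limit of the assay and not a number. Compound 1 also stands at a limit, and the step between compound 1 and compound 3 cannot be read. The compounds shown leave open at what concentration any of them reaches its half-maximal cytotoxic effect.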